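Benzyl-substituted purine series: cytotoxicity on UO-31 cells

The source may report more compounds than this note shows. Statements on the series, on what has been measured and on what is new or still open speak of the compounds shown alone.

Measured so far:
- compound 1, `ClCc1ccccc1Cn1cnc2c(Cl)nc(Cl)nc21`: 5920 nM
- compound 2, `ClCc1cccc(Cn2cnc3ncnc(Cl)c32)c1`: 26900 nM

In a functional assay on UO-31 cells (Homo sapiens) for cytotoxicity, read by sulforhodamine B assay, with a stated time of 48 h (on this read-out higher numbers stand for lower toxicity in this test and lower numbers for higher toxicity in this test), compound 1 gives 5920 nM and holds the lowest number of the two measured compounds. Compound 2 gives 26900 nM in this assay, a gap that goes beyond the scatter of repeated measurements. For the measured compounds named here, compound 2 differs from compound 1 in more than one place, so the two values show only that compound 1 is the more toxic of the pair in this assay, and nothing about any single change.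

Compound 3, `Nc1nc(Cl)c2ncn(Cc3ccccc3CCl)c2n1`, has not yet been measured in this assay. It differs from compound 1 by amino in place of chloro on an aromatic carbon. Going by the values given here, no measured pair shows this change on its own, so the size of the step is open. Among the compounds with values here, with no comparable step at hand, the expected step of a 2.0-fold higher number from compound 1 to compound 3 (0.31 log units; beyond the scatter) is modest, towards a higher number, but a result within the scatter would not surprise. For compound 3 the estimate in this assay is 12000 nM, with a range from 4000 nM to 40000 nM.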

Compound 3, concentration lethal to 50% of the cells: > 100000 nM
Compound 3 ended at the assay's limit; the forecaster's own chance of this, stated with the estimate: 15%; middle value at least 8.3-fold (0.92 log units) from the limit.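

In this assay, for the compounds shown here, amino in place of chloro on an aromatic carbon, between two ring nitrogen atoms, gives an at least 16-fold higher number from compound 1 to compound 3 (1.22 log units; beyond the scatter); this is the first step that can be read at a single place, and it is large. Compound 3 sits at a limit of the assay, > 100000 nM, which is not a number, so the step has a floor but no upper bound: the limit of > 100000 nM in this assay, at which 1 of the 3 values shown sits.

The change shows that this position is not a silent one in this assay: the second chloro group and the rest of the core of compound 1 stay in place in compound 3, yet they do not keep the read-out near that of compound 1.

Going by these compounds alone, the single step cannot separate the loss of chloro from the arrival of amino, and a hydrogen, a methoxy group or a methylamine at the same carbon would be needed to tell the two apart. On these data alone, whether the same change has a similar effect on a compound with a different benzyl substitution also remains open, as does the size of the step beyond the limit.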